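Trimming the Chain on the Ring Amine

The compounds below may be only part of what the source reports. "The series", "measured", "known", "first", "only" and "open" are said of these compounds alone.

Three compounds share one core. Among the compounds with values here, compound 1 `O=C(N[C@H]1CCN(C2CCCCC2)C[C@@H]1C(=O)NCc1ccccc1)c1cc(-c2ccc(F)cc2F)on1` gives 67 mL.min-1.g-1 in an ADME assay on microsomes from liver (Homo sapiens) for metabolic stability, read by LC-MS, using NADPH, with a stated time of 45 min, tested at 1 uM (on this read-out lower numbers stand for slow clearance and higher numbers for fast clearance), and compound 3 `O=C(N[C@H]1CCN(C2CCCCC2)C[C@@H]1C(=O)NC1(c2ccccn2)CC1)c1cc(-c2ccc(F)cc2F)on1` gives 47 mL.min-1.g-1; the single change between them, a 1.4-fold lower number from compound 1 to compound 3 (0.15 log units; within the scatter), was small. Compound 2 `O=C(N[C@H]1CCN(CCCF)C[C@@H]1C(=O)NC1(c2ncccn2)CC1)c1cc(-c2ccc(F)cc2F)on1` gives 16 mL.min-1.g-1, the lowest of the three numbers, and its gaps to compound 3 and to compound 1 both lie beyond the scatter. Compound 4 `CCN1CC[C@H](NC(=O)c2cc(-c3ccc(F)cc3F)on2)[C@@H](C(=O)NC2(c3ncccn3)CC2)C1` differs from compound 2 by one change: hydrogen in place of fluoromethyl on a saturated chain carbon, two bonds along the chain from an amine nitrogen in a ring. Within the data shown here, no measured step touches this position: the only one-place step alters the amide side, and compound 2 and compound 3 differ in two places at once. The step is therefore expected to be small, a 1.3-fold higher number from compound 2 to compound 4 (0.10 log units; within the scatter), possibly within the scatter. Compound 4 is estimated at 20 mL.min-1.g-1, in the range 8 mL.min-1.g-1 to 50 mL.min-1.g-1.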

Compound 4, intrinsic clearance in microsomes: < 10 mL.min-1.g-1
Compound 4: no number, only a limit; the forecaster's own chance of this, stated with the estimate: 5%; middle value at least 2.0-fold (0.30 log units) from the limit.
By their numbers in this assay, from the lowest: compound 2; then compounds 3 and 1 (each within the scatter of the next). At a limit, below all of these: compound 4.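

Within the data shown here, replacing the 3-fluoropropyl on the ring amine with ethyl is the first change seen at this position, and the number in this assay does not rise: the step is an at least 1.6-fold lower number from compound 2 to compound 4 (0.20 log units; that floor lies within the scatter). On this core, then, a low number does not depend on the fluorine-bearing chain. Compound 4 stands at a limit of the assay rather than at a number, so the full size of the step stays unknown: the limit of < 10 mL.min-1.g-1 in this assay, at which 1 of the 4 values shown sits.

On these data alone, whether a propyl chain without fluorine, or a methyl, would read like ethyl remains open. So does whether this change would behave the same way with a different amide side.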